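Series notes: sulfonamide variation on the shared aryl-alkyne acid core

The source may report more compounds than this note shows. Statements on the series, on what has been measured and on what is new or still open speak of the compounds shown alone.

Measured so far in an assay on CHO cells for displacement of a labelled ligand from prostaglandin D2 receptor 2 (Homo sapiens), read by scintillation counting; a lower number here means a stronger inhibitor, a higher number a weaker inhibitor:
compound 1 `COCCN(C)S(=O)(=O)c1ccc(C)c(C#Cc2cc(Cl)ccc2OCC(=O)O)c1` gives 4.1 nM
compound 2 `CCCS(=O)(=O)c1cccc(C#Cc2c(Cl)cccc2OCC(=O)O)c1` gives 55 nM
compound 3 `CS(=O)(=O)c1cncc(C#Cc2cc(Cl)ccc2OCC(=O)O)c1` gives 60 nM

For the measured compounds named here, compound 1 stands lowest of the three numbers; compound 2 and compound 3 both sit well beyond the scatter above it, and no single-point step between any two of these measured compounds is available. Compound 4 `Cc1ccc(S(=O)(=O)N2CCCCC2C)cc1C#Cc1cc(Cl)ccc1OCC(=O)O` has not yet been measured in this assay. It differs from compound 1 in one place: 2-methylpiperidin-1-yl in place of (2-methoxyethyl)(methyl)amino on a sulfonyl sulfur. Going by the values given here, no step of this kind has been measured, so the expectation rests only on compound 1 and the change itself. The step of a 1.5-fold higher number from compound 1 to compound 4 (0.17 log units; within the scatter) is expected to be small, if anything a slight weakening, and likely within the scatter. Compound 4 is therefore estimated at 6 nM, with a range from 2 nM to 20 nM.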

Compound 4, inhibition constant: 1.9 nM
Beside the measured number, compound 4's estimate is 3.2-fold (0.50 log units) above it, and the stated range ends above it.
By their numbers in this assay, from the lowest: compound 4; then compound 1; then compounds 2 and 3 (each within the scatter of the next).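

In this assay, the sulfonyl sulfur accepts 2-methylpiperidin-1-yl in place of the open chain (2-methoxyethyl)(methyl)amino, with a 2.2-fold lower number from compound 1 to compound 4 (0.33 log units; beyond the scatter). For the compounds shown here, this is the first single-place step, and it shows that the hydrogen-bond acceptor counted on the leaving group is not needed to reach a low number in this pair. Nothing measured accounts for the step.

The compounds shown leave open how much of the step belongs to the ring and how much to its methyl group. Unsubstituted piperidin-1-yl or morpholin-4-yl on the same sulfur would separate the two.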